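The source may report more compounds than this note shows. Statements on the series, on what has been measured and on what is new or still open speak of the compounds shown alone.

Within the data shown here, compound 2 `COc1ccccc1-c1nnc(-c2ccc(C(=O)N/N=C/c3ccc(O)cc3)cc2)o1` gives 261000 nM in an ADME assay on THP-1 cells (Homo sapiens) for cytotoxicity; a lower number here means a stronger inhibitor, a higher number a weaker inhibitor; only one other compound has been measured, compound 1 `COc1ccc(/C=N/NC(=O)c2ccc(-c3nnc(-c4ccccc4OC)o3)cc2)cc1O` with 260000 nM, and the two lie within the scatter of each other. Among the measured compounds shown here, the single measured step, a 1.0-fold higher number from compound 1 to compound 2 (0.00 log units; within the scatter), exchanged the group on the carbon with a double bond to nitrogen without moving the number beyond the scatter. Compound 3 `COc1ccccc1-c1nnc(-c2ccc(C(=O)N/N=C/c3cccc([N+](=O)[O-])c3)cc2)o1` varies the same place again: 3-nitrophenyl in place of 4-hydroxyphenyl on a carbon with a double bond to nitrogen. For the measured compounds named here, no measured step introduces a 3-nitrophenyl, so the step from compound 1 to compound 2 is the only guide, and it suggests that an exchange at this position leaves this assay unchanged. Compound 3 is therefore expected to give about 250000 nM, with a range of 90000 nM to 700000 nM. That estimate amounts to a step of a 1.0-fold lower number from compound 2 to compound 3 (0.02 log units; within the scatter), nothing beyond the scatter.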

Compound 3, half-maximal inhibitory concentration: 119000 nM
Estimate against measurement, compound 3: 2.1-fold (0.32 log units) above, within the range that was stated.
By their numbers in this assay, from the lowest: compound 3; then compounds 1 and 2 (each within the scatter of the next).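

In this assay the place on a carbon with a double bond to nitrogen can now move the number beyond the scatter, which the earlier exchange between the two hydroxyphenyl groups did not show: 3-nitrophenyl gives a 2.2-fold lower number from compound 2 to compound 3 (0.34 log units; beyond the scatter) and a 2.2-fold lower number from compound 1 to compound 3 (0.34 log units; beyond the scatter) on the same core. Both steps are modest and equal in size, so the two hydroxyphenyl groups serve as one reference point for this change.

Compound 3 gains the nitro group and loses the hydroxyl in a single exchange, and the compounds shown do not separate the two. Also open, going by these compounds, is how an aminophenyl or a carboxyphenyl would read on the same carbon. No measurement on hand explains the shift.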